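The source may hold more compounds than are shown below. What is called first, only, known or untested is meant among the compounds shown, and "the series" means these compounds.

Measured in a physicochemical assay, with a stated time of 6 min; on this read-out higher numbers stand for weaker inhibition and lower numbers for stronger inhibition:
- Compound 1 `O=C(Nc1ccc(F)cc1)Nc1nc(-c2cc3ccccc3o2)cs1`: 1130 nM
- Compound 2 `O=C(Nc1nc(-c2cc3ccccc3o2)cs1)Nc1ccccc1F`: 2630 nM
- Compound 3 `O=C(Nc1nc(-c2cc3cc(Br)ccc3o2)cs1)Nc1ccccc1F`: > 200000 nM, a limit and not a number

Compound 3 is known only as a limit, with the limit of > 200000 nM in this assay, at which 1 of the 3 values shown sits. Compound 4 `O=C(Nc1ccccc1)Nc1nc(-c2cc3cc(Br)ccc3o2)cs1` differs from it by hydrogen in place of fluoro on an aromatic carbon, ortho to a large group: hydrogen in place of fluoro on an aromatic carbon. The closest measured change on this aromatic ring is modest, a 2.3-fold higher number from compound 1 to compound 2 (0.37 log units; beyond the scatter), and it moves the fluoro rather than removing it. The large step, an at least 76-fold higher number from compound 2 to compound 3 (1.88 log units; beyond the scatter), came with the bromo, which compound 4 keeps. In this assay only a modest step towards a lower number is therefore expected, and the limit may well be reached again. The expected step is an at least 1.6-fold lower number from compound 3 to compound 4 (0.22 log units; that floor lies within the scatter). Compound 4 is estimated at 120000 nM, with an expected range from 15000 nM to 200000 nM.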

Compound 4, half-maximal inhibitory concentration: > 200000 nM
Compound 4: no number, only a limit; the forecaster's own chance of this, stated with the estimate: 50%; middle value at least 1.6-fold (0.22 log units) from the limit.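

For the compounds shown here, no step from compound 3 to compound 4 can be read, because each gives a limit and not a number: the limit of > 200000 nM in this assay, at which 2 of the 4 values shown sit. Left open is whether hydrogen in place of fluoro changes inhibition in these bromo compounds at all.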